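Swapping the benzyl substituent: expected Vero cell cytotoxicity

A few compounds are considered here, and "the series" means these few. Any claim that something is new, unique, unknown or untested is made for them only; others in the source may bear on it.

Compound 1 `CCOC(=O)c1cc(-c2cccc(OCc3cccc(C#N)c3)c2)on1` — > 128000 nM
Compound 2 `CCOC(=O)c1cc(-c2cccc(OCc3cccc(N)c3)c2)on1` — > 128000 nM

In an ADME assay on Vero cells (Chlorocebus sabaeus) for cytotoxicity, with a stated time of 72 h (a lower number here means a stronger inhibitor, a higher number a weaker inhibitor), compound 1 gives > 128000 nM, which is a limit of the assay. Compound 2 gives > 128000 nM in this assay, likewise a limit. The step that the two limits leave unreadable from compound 1 to compound 2 cannot be sized because of the limit of > 128000 nM in this assay, at which 2 of the 2 values shown sit. Compound 3 `CCOC(=O)c1cc(-c2cccc(OCc3ccccc3Cl)c2)on1` differs from compound 2 by 2-chlorophenyl in place of 3-aminophenyl on a saturated chain carbon bound to an oxygen on an aromatic ring. No measured step reads on this change, and both shown values rest at the limit. The expected step is a step that the limit leaves unreadable from compound 2 to compound 3, meaning no movement beyond the scatter. Compound 3 is accordingly estimated at 150000 nM, with a range from 50000 nM to 500000 nM.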

Compound 3, half-maximal inhibitory concentration: > 128000 nM
Compound 3 ended at the assay's limit (the forecaster's own chance of this, stated with the estimate: 85%); the middle value does not contradict the limit.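

No new step can be read among compound 1, compound 2 and compound 3, because all three rest at a limit: the limit of > 128000 nM in this assay, at which 3 of the 3 values shown sit. On these data alone, whether swapping the benzyl substituent moves the read-out at all in this assay stays open.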